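A few compounds are considered here, and "the series" means these few. Any claim that something is new, unique, unknown or untested is made for them only; others in the source may bear on it.

Measured compounds:
compound 1 `Cc1nc2c(OCc3ccccc3)cccn2c1N` — 99%
compound 2 `Cc1nc2c(OCc3ccccc3)cccn2c1NCc1ccccc1` — 48%

In a functional assay on the whole organism with Rattus norvegicus as the target, at a dose of 40 mg/kg by the intraperitoneal route (a higher number here means more inhibition at the dose given (going by the name of the read-out), a lower number less inhibition), compound 1 gives 99%, and compound 2 gives 48%. For the measured compounds named here, the only measured step, a number 51 percentage points lower from compound 1 to compound 2 (beyond the scatter), is benzyl in place of hydrogen on a nitrogen on an aromatic ring. Going by the values given here, compound 2 therefore stands lowest of the two numbers known, with compound 1 as its nearest neighbour beyond the scatter.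

Compound 3 `CCCN(CCC)c1c(C)nc2c(OCc3ccccc3)cccn12` is not yet measured. It differs from compound 2 by dipropylamino in place of benzylamino on an aromatic carbon. Among the compounds with values here, no measured step bears directly on this change; the only step known, a number 51 percentage points lower from compound 1 to compound 2 (beyond the scatter), shows that substitution on this nitrogen lowered the read-out in this assay by a large amount, and compound 3 carries two substituents there and keeps no hydrogen-bond donor. The expectation for compound 3 is thus a further fall or, at best, no step beyond the scatter: a number 13 percentage points lower from compound 2 to compound 3 (beyond the scatter). Compound 3 is estimated at 35%, with a range from 10% to 65%.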

Compound 3, a percentage reported as inhibition, in the whole organism at one dose (the size of the read-out at that dose, not a potency): 60%
Compound 3: the middle estimate sits 25 percentage points below what was measured; the measured number falls inside the stated range.
By their numbers in this assay, from the lowest: compound 2; then compound 3; then compound 1.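

In this assay, substitution on this nitrogen does not lower the number in step with the size of the change: dipropylamino in place of benzylamino gives a number 12 percentage points higher from compound 2 to compound 3 (beyond the scatter), so the loss of the hydrogen-bond donor and of the six-membered aromatic ring does not take compound 3 below compound 2. Dipropylamino in place of amino still gives a number 39 percentage points lower from compound 1 to compound 3 (beyond the scatter), which leaves the unsubstituted amine of compound 1 highest of the three, with its steps to both others beyond the scatter. No evidence is available to explain the order of the three compounds.

Open, going by these compounds, is whether a smaller group on this nitrogen, such as methylamino or ethylamino, stays near compound 1. On these data alone, a ring amine such as morpholine or piperidine at this place is also open, as is a longer chain than propyl.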